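The compounds below may be only part of what the source reports. "The series", "measured", "known", "first", "only" and "open" are said of these compounds alone.

Compound 1 is `O=C1C=CC(=O)C(c2cc(-c3ccc(C(=O)N4CCC(C(F)(F)F)CC4)s3)on2)=C1` and in a functional assay on A549 cells (Homo sapiens) for cytotoxicity, read by XTT assay, with a stated time of 72 h (on this read-out lower numbers stand for stronger inhibition and higher numbers for weaker inhibition), compound 1 gives > 30000 nM, which is a limit of the assay rather than a number. Compound 2 is `CCN(CC)C(=O)c1ccc(-c2cc(C3=CC(=O)C=CC3=O)no2)s1` and in this assay compound 2 gives 10000 nM.

Among the measured compounds shown here, compound 2 therefore holds the only actual number in this assay; the value of compound 1 sits at the limit of > 30000 nM in this assay, at which 1 of the 2 values shown sits. Between them lies one step, an at least 3.0-fold lower number from compound 1 to compound 2 (0.47 log units; beyond the scatter), in which diethylamino replaces 4-(trifluoromethyl)piperidin-1-yl on the carbonyl carbon.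

Compound 3 is `O=C1C=CC(=O)C(c2cc(-c3ccc(C(=O)N4CCCCC4)s3)on2)=C1`. It differs from compound 2 by piperidin-1-yl in place of diethylamino on a carbonyl carbon. The entering piperidin-1-yl is the ring of compound 1 without its trifluoromethyl, so the new step runs part of the way back along the measured step of an at least 3.0-fold lower number from compound 1 to compound 2 (0.47 log units; beyond the scatter). That step was at least modest and went toward stronger inhibition when the ring left; returning a plain ring is expected to move the number the other way, though the measured step gives no reading for the ring without trifluoromethyl. The step in this assay is estimated as a 1.6-fold higher number from compound 2 to compound 3 (0.20 log units; within the scatter), somewhat weaker inhibition. Compound 3 is expected at 16000 nM, between 6000 nM and 40000 nM.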

Compound 3, half-maximal inhibitory concentration: > 30000 nM
Compound 3 ended at the assay's limit; the forecaster's own chance of this, stated with the estimate: 30%; at least 1.8-fold (0.27 log units) between middle value and limit.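

In this assay, replacing diethylamino with piperidin-1-yl on the carbonyl carbon gives an at least 3.0-fold higher number from compound 2 to compound 3 (0.47 log units; beyond the scatter), so this change costs inhibition even with no trifluoromethyl on the ring. The earlier compounds shown here could not separate the ring from its trifluoromethyl, but compound 3 shows that the plain ring is also enough to reach the limit of the assay, which is a bound and not a measured number. Whether removing the trifluoromethyl changes inhibition at all remains hidden, and the step from compound 1 to compound 3 cannot be read because both values are limits: the limit of > 30000 nM in this assay, at which 2 of the 3 values shown sit.

Among these three compounds, only the open-chain diethylamino amide gives an actual number, but three compounds cannot show whether an open chain in general is what matters at this carbonyl carbon. A shorter open chain such as dimethylamino, or a smaller ring such as pyrrolidin-1-yl, would help show whether inhibition depends on the ring itself or on the particular amine, and morpholin-4-yl would test a second hetero atom in the ring.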